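The compounds below may be only part of what the source reports. "The series", "measured", "known", "first", "only" and "open" are said of these compounds alone.

Measured so far in a physicochemical assay for solubility, in simulated intestinal fluid (on this read-out higher numbers stand for higher solubility and lower numbers for lower solubility), for three compounds:
- compound 1 `Cc1nc(C)n(CC(=O)N2CCN(c3sc(C(F)(F)F)nc3-c3nc4c(F)cccc4[nH]3)C[C@H]2C)n1` gives 750 ug/mL
- compound 2 `C[C@@H]1CN(c2sc(C(F)(F)F)nc2-c2nc3ccccc3[nH]2)CCN1C(=O)Cn1cccn1` gives 734 ug/mL
- compound 3 `Cc1nc(C)n(CC(=O)N2CCN(c3sc(C(F)(F)F)nc3-c3nc4ccc(C5CCOCC5)cc4[nH]3)C[C@H]2C)n1` gives > 1000 ug/mL as a limit, not a number

Compound 2 at 734 ug/mL and compound 1 at 750 ug/mL lie within the scatter of each other. Compound 3 gives only a limit. Compound 4 `C[C@@H]1CN(c2sc(C(F)(F)F)nc2-c2nc3ccccc3[nH]2)CCN1C(=O)Cn1cnc2c1CCN(C)C2` departs from compound 2 by one change a group of 10 heavy atoms (7 carbon, 3 nitrogen; one five-membered aromatic ring with 2 hetero atoms, one six-membered non-aromatic ring with 1 hetero atom) in place of a group of 5 heavy atoms (3 carbon, 2 nitrogen; one five-membered aromatic ring with 2 hetero atoms), on a saturated chain carbon bound to a carbonyl carbon on a saturated chain carbon bound to a carbonyl carbon, where 1H-pyrazol-1-yl leaves. Among the compounds with values here, no measured pair shows this change, so in this assay only a small upward step is expected, none beyond the scatter. The expected move is a 1.2-fold higher number from compound 2 to compound 4 (0.09 log units; within the scatter) in this estimate. For compound 4 the estimated value is 900 ug/mL with an expected range from 420 ug/mL to 1600 ug/mL in the same read-out.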

Compound 4, solubility: > 920 ug/mL
Compound 4: a limit, no number; the forecaster's own chance of this, stated with the estimate: 40%; at least 1.0-fold (0.00 log units) between middle value and limit.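

In this assay compound 4 gives > 920 ug/mL, which is a limit and not a number. Going by these compounds, the change on the saturated chain carbon bound to a carbonyl carbon, where 1H-pyrazol-1-yl leaves, can be read only as an at least 1.2-fold higher number from compound 2 to compound 4 (0.09 log units; that floor lies within the scatter), so the full size of the step stays unknown. Within the data shown here, it is the first single-change comparison at this position, and it shows that the position carries the larger group, with its six-membered non-aromatic ring, without the read-out falling under that floor.

The compounds shown leave open where the true value of compound 4 lies. They also leave open how an open-chain amine or a carboxylic acid would read at this position.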